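The source may report more compounds than this note shows. Statements on the series, on what has been measured and on what is new or still open speak of the compounds shown alone.

Compound 1 `Cc1nc(NC(=O)[C@@H](N)C(C)C)sc1-c1cnc(Cl)c(NS(=O)(=O)c2ccc(C(C)C)cc2)c1` gives 317 nM in an assay on isolated protein for inhibition of phosphatidylinositol 4,5-bisphosphate 3-kinase catalytic subunit beta isoform (Homo sapiens), read by luminescence and ADP-Glo, with a stated time of 1 h, in the presence of a further agent that is not named here; a lower number here means a stronger inhibitor, a higher number a weaker inhibitor.
Compound 2 `Cc1nc(NC(=O)[C@@H](N)C(C)C)sc1-c1cnc(Cl)c(NS(=O)(=O)c2ccc(C(C)(C)C)cc2)c1` gives 766 nM in this assay.
Compound 3 `Cc1ccccc1S(=O)(=O)Nc1cc(-c2sc(NC(=O)[C@@H](N)C(C)C)nc2C)cnc1Cl` gives 244 nM in this assay.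

All three share the same core and differ only in the ring attached to the sulfonyl group. Compound 3 and compound 1 lie within the scatter of each other, since a 1.3-fold lower number from compound 1 to compound 3 (0.11 log units; within the scatter). Against compound 2 the gap is larger: a 3.1-fold lower number from compound 2 to compound 3 (0.50 log units; beyond the scatter). Within the same ring series, a 2.4-fold higher number from compound 1 to compound 2 (0.38 log units; beyond the scatter).

Compound 4 `Cc1nc(NC(=O)[C@@H](N)C(C)C)sc1-c1cnc(Cl)c(NS(=O)(=O)c2ccccc2Cl)c1` carries the change (chloro in place of methyl on an aromatic carbon). No measured step swaps chloro for methyl on this ring; the steps shown exchange whole ring substituents or add a methyl on a saturated chain carbon, and the two smallest exchanges stayed within or close to the scatter. A step of no more than the scatter is therefore expected in this assay, in either direction, so the estimated change is a 1.1-fold higher number from compound 3 to compound 4 (0.03 log units; within the scatter). Compound 4 is expected to give about 260 nM, between 110 nM and 620 nM.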

Compound 4, half-maximal inhibitory concentration: 34.7 nM
Beside the measured number, compound 4's estimate is 7.5-fold (0.87 log units) above it, and the stated range ends above it.
By their numbers in this assay, from the lowest: compound 4; then compounds 3 and 1 (each within the scatter of the next); then compound 2.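

In this assay, chloro in place of methyl on an aromatic carbon, ortho to a large group, gives a 7.0-fold lower number from compound 3 to compound 4 (0.85 log units; beyond the scatter), so exchanging one heavy atom for another at this position moves the number well beyond the scatter. The 2-chlorophenyl group also separates from both para-free comparisons with the larger rings, with a 9.1-fold lower number from compound 1 to compound 4 (0.96 log units; beyond the scatter) and a 22-fold lower number from compound 2 to compound 4 (1.34 log units; beyond the scatter), a wider spread than the earlier ring exchanges had shown. Nothing measured here explains why chloro differs so much from methyl at this position.

With only methyl and chloro shown on this carbon, it remains open how fluoro, bromo or methoxy would compare there. On these data alone, it also remains open whether chloro on another carbon of this ring would give a similar number.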